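Fluoro in place of a charged group on the aryl ring

The compounds below may be only part of what the source reports. "The series", "measured", "known", "first", "only" and "open" are said of these compounds alone.

Measured so far:
compound 1 `COC(=O)C1=C(C)N=C(C)/C(=C(\O)OC)C1c1ccc(F)cc1` — 129 nM
compound 2 `COC(=O)C1=C(C)N=C(C)/C(=C(\O)OC)C1c1cccc([N+](C)(C)C)c1` — 50100 nM

In a functional assay (muscle tissue) with Cavia porcellus as the target (on this read-out lower numbers stand for an effect already at smaller amounts and higher numbers for an effect only at larger amounts of compound), compound 2 stands highest of the two numbers; the nearest is compound 1, with a markedly lower number, and the gap between them lies beyond the scatter. Compound 3 `COC(=O)C1=C(C)N=C(C)/C(=C(\O)OC)C1c1cccc(F)c1` is not yet measured. It differs from compound 2 in one place: one fluorine atom in place of a group of 4 heavy atoms (3 carbon, 1 nitrogen; no ring), on an aromatic carbon. Compound 1 also carries fluoro on its aromatic ring and gives 129 nM, so a large step downward is expected in this assay, expressed as an 840-fold lower number from compound 2 to compound 3 (2.92 log units; beyond the scatter). Compound 3 is estimated at 60 nM, with a range from 10 nM to 400 nM.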

Compound 3, half-maximal effective concentration: 20.9 nM
Estimate against measurement, compound 3: 2.9-fold (0.46 log units) above; low and high end bracket the measured number.
By their numbers in this assay, from the lowest: compound 3; then compound 1; then compound 2.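

In this assay, fluoro in place of the charged group gives a 2400-fold lower number from compound 2 to compound 3 (3.38 log units; beyond the scatter) and is by far the larger change at this aromatic carbon. 3-fluorophenyl in place of 4-fluorophenyl gives a 6.2-fold lower number from compound 1 to compound 3 (0.79 log units; beyond the scatter) and shows that the place of the fluoro on the ring also counts, though much less. No available measurement explains either step. From the compounds shown here alone, whether tert-butyl or an amine at this place would stay close to compound 3 remains open. The compounds shown therefore cannot separate the charge of the leaving group from its size.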